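The source may report more compounds than this note shows. Statements on the series, on what has been measured and on what is new or still open speak of the compounds shown alone.

Measured so far:
compound 1, `COc1cc(C(=O)N/N=C/c2ccccc2C(F)(F)F)cc(OC)c1OC`: 52.9%
compound 2, `COc1ccc(OC)c(C2OC(c3cc(OC)c(OC)c(OC)c3)=NN2C(C)=O)c1`: 43.2%

In a functional assay on PC-3 cells (Homo sapiens) for antiproliferative activity, read by MTT assay, tested at 5 uM (on this read-out lower numbers stand for a weaker effect and higher numbers for a stronger effect at the one concentration tested), compound 2 gives 43.2%, the lower of the two numbers, though compound 1 at 52.9% sits within the scatter of it, so no real order between the two can be claimed. Compound 3, `COc1cc(C2=NN(C(C)=O)C(c3cccc(F)c3)O2)cc(OC)c1OC`, differs from compound 2 by 3-fluorophenyl in place of 2,5-dimethoxyphenyl on a saturated ring carbon. Within the data shown here, no step between measured compounds is available, and the change has no measured parallel in this pair. Since the two numbers in hand differ only within the scatter, a step of a number 1.8 percentage points higher from compound 2 to compound 3 (within the scatter) is expected, nothing beyond the scatter in either direction. Compound 3 is estimated at 45%, in the range 30% to 60%.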

Compound 3, a percentage reported as inhibition, at one concentration (the size of the read-out at that concentration, not a potency): 43.5%
Estimate against measurement, compound 3: 1.5 percentage points above, within the range that was stated.
By their numbers in this assay, from the lowest: compounds 2, 3 and 1 (each within the scatter of the next).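

In this assay, among these compounds, the move to 3-fluorophenyl in place of 2,5-dimethoxyphenyl on the saturated ring carbon gives a number 0.3 percentage points higher from compound 2 to compound 3 (within the scatter), the first comparison that differs in one place. At the one concentration tested, this position therefore accepts a smaller group carrying no hydrogen-bond acceptors with no change beyond the scatter. No measurement available here accounts for this result. Still open, going by these compounds, is whether an amine or a carboxylic acid on that ring carbon would move the read-out beyond the scatter.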